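This account rests on a few compounds, and the source may have more. Where it says the series, first, only, none or still open, it means among the compounds named here.

Measured so far in a functional assay on SH-SY5Y cells (Homo sapiens), read by MTT assay, with a stated time of 24 h; on this read-out lower numbers stand for an effect already at smaller amounts and higher numbers for an effect only at larger amounts of compound: compound 1 `COc1ccc(Cl)cc1N(CC(=O)Nc1cccc2ccccc12)S(=O)(=O)c1ccccc1` gives 17400 nM. Compound 2 `COc1ccc(Cl)cc1N(CC(=O)Nc1ccc(Cl)cc1)S(=O)(=O)c1ccccc1` reaches only the assay limit, > 20000 nM. Compound 3 `CCCNC(=O)CN(c1cc(Cl)ccc1OC)S(=O)(=O)c1ccccc1` likewise reaches only the assay limit, > 20000 nM.

Compound 3 thus stands at the edge of the measurable range, where the limit of > 20000 nM in this assay, at which 2 of the 3 values shown sit, applies, with no number of its own. Compound 4 `COc1ccc(Cl)cc1N(CC(=O)Nc1ccc([N+](=O)[O-])cc1)S(=O)(=O)c1ccccc1` differs from it by 4-nitrophenyl in place of propyl on an amide-type nitrogen. The steps that touch compound 3 are an at least 1.1-fold higher number from compound 1 to compound 3 (0.06 log units; that floor lies within the scatter) and a step that the two limits leave unreadable from compound 2 to compound 3; neither gives a readable size. Compound 2, the nearest aryl amide to compound 4 in this series, sits at its limit as well. The change from compound 3 to compound 4 is therefore expected to move this assay little, with an expected step that the limit leaves unreadable from compound 3 to compound 4. Compound 4 is estimated at 25000 nM, between 8000 nM and 80000 nM, and most likely again only a limit.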

Compound 4, half-maximal effective concentration: 8210 nM
Estimate against measurement, compound 4: 3.0-fold (0.48 log units) above; the measured number falls inside the stated range.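

In this assay, a change on the aryl group now has a readable effect: nitro in place of chloro on an aromatic carbon gives an at least 2.4-fold lower number from compound 2 to compound 4 (0.38 log units; beyond the scatter), and 4-nitrophenyl in place of propyl on the amide-type nitrogen gives an at least 2.4-fold lower number from compound 3 to compound 4 (0.38 log units; beyond the scatter). Against the larger aryl group, 4-nitrophenyl in place of naphthalen-1-yl gives a 2.1-fold lower number from compound 1 to compound 4 (0.33 log units; beyond the scatter). The first two steps are only floors, since compound 2 and compound 3 each sit at a limit: the limit of > 20000 nM in this assay, at which 2 of the 4 values shown sit.

Still open, as far as these compounds go, is whether a nitrile, an amine or a carboxylic acid on that aromatic carbon would match nitro.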